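The compounds below may be only part of what the source reports. "The series", "measured", "known", "first", "only" and "open" are said of these compounds alone.

In a functional assay on A549 cells (Homo sapiens) for inhibition, read by MTT assay, with a stated time of 72 h (on this read-out lower numbers stand for stronger inhibition and higher numbers for weaker inhibition), compound 1 `CC1=NN(c2ccccc2)C(=O)[C@@]12C(=O)C=CC[C@H]2c1cccc(C)c1` gives 3500 nM. Two compounds differing from it only in configuration stand level with it: compound 2 `CC1=NN(c2ccccc2)C(=O)[C@@]12C(=O)C=CC[C@@H]2c1cccc(C)c1` gives 4510 nM and compound 3 `CC1=NN(c2ccccc2)C(=O)[C@]12C(=O)C=CC[C@@H]2c1cccc(C)c1` gives 4770 nM. Compound 1 thus holds no separate place among the three. Compound 4 `CC1=NN(c2ccccc2)C(=O)[C@@]12C(=O)C=CC[C@H]2c1ccccc1` carries hydrogen in place of methyl on an aromatic carbon, meta to a large group, so 3-methylphenyl becomes phenyl (hydrogen in place of methyl on an aromatic carbon). For the measured compounds named here, the only measured steps are configurational: a 1.3-fold higher number from compound 1 to compound 2 (0.11 log units; within the scatter), a 1.4-fold higher number from compound 1 to compound 3 (0.13 log units; within the scatter) and a 1.1-fold higher number from compound 2 to compound 3 (0.02 log units; within the scatter), each within the scatter. None tests the methyl, so they set no direction, and no step beyond the scatter is expected. The expected step is a 1.1-fold higher number from compound 1 to compound 4 (0.06 log units; within the scatter). Compound 4 is estimated at 4000 nM, with an expected range of 1800 nM to 9000 nM.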

Compound 4, half-maximal inhibitory concentration: 3770 nM
For compound 4 the middle estimate is 1.1-fold (0.03 log units) above the measured one, within the range that was stated.
By their numbers in this assay, from the lowest: compounds 1, 4, 2 and 3 (each within the scatter of the next).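

In this assay, the change from 3-methylphenyl to phenyl gives a 1.1-fold higher number from compound 1 to compound 4 (0.03 log units; within the scatter). For the compounds shown here, this is the first step that alters atoms rather than configuration, and the methyl at this place proves dispensable for the activity level of the series in this read-out. Nothing on record bears on this methyl-to-hydrogen step. Only methyl and hydrogen are compared at this place, and only in the configuration of compound 1. Going by these compounds, whether methoxy, an amine or a carboxylic acid there would keep the number level stays open, as does whether phenyl keeps it in the other configurations.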